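Two Methoxy Groups Added to an Anilino Ring

This account rests on a few compounds, and the source may have more. Where it says the series, first, only, none or still open, it means among the compounds named here.

Measured so far:
- compound 1, `C=CC(=O)Nc1cccc(NC(=O)CSc2nc(Nc3cccc(Cl)c3)c3ccccc3n2)c1`: 16300 nM
- compound 2, `C=CC(=O)Nc1cccc(NC(=O)CSc2nc(Nc3cccc(OC)c3)c3ccccc3n2)c1`: 12900 nM

Both compounds were tested in a functional assay on MDA-MB-231 cells (Homo sapiens) for inhibition, read by MTT assay, with a stated time of 72 h; a higher number here means a weaker inhibitor, a lower number a stronger inhibitor. Compound 2 holds the lowest of the two numbers, with compound 1 nearest to it; the difference between them, a 1.3-fold lower number from compound 1 to compound 2 (0.10 log units; within the scatter), lies within the scatter, so the two cannot be told apart.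

Compound 3, `C=CC(=O)Nc1cccc(NC(=O)CSc2nc(Nc3cc(OC)c(OC)c(OC)c3)c3ccccc3n2)c1`, has not yet been measured. It differs from compound 2 in one place: 3,4,5-trimethoxyphenyl in place of 3-methoxyphenyl on a nitrogen on an aromatic ring.

Among the compounds with values here, only one measured step bears on this change, the swap from chloro to methoxy between compound 1 and compound 2, and it moved the number by a 1.3-fold lower number from compound 1 to compound 2 (0.10 log units; within the scatter), which is within the scatter. Within the data shown here, no measured pair shows what adding two further methoxy groups to the same ring does, so there is no basis for expecting a step beyond the scatter in this assay in either direction. For compound 3 the expected step is therefore a 1.1-fold lower number from compound 2 to compound 3 (0.03 log units; within the scatter). Compound 3 is estimated at 12000 nM, with a range from 4000 nM to 36000 nM.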

Compound 3, half-maximal inhibitory concentration: > 50000 nM
Compound 3: a limit, no number (the forecaster's own chance of this, stated with the estimate: 10%); at least 4.1-fold (0.61 log units) between middle value and limit.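

Compound 3 gives no number in this assay, only a limit of the assay: the limit of > 50000 nM in this assay, at which 1 of the 3 values shown sits.

Within the data shown here, the earlier swap of chloro for methoxy on the anilino ring gave a 1.3-fold lower number from compound 1 to compound 2 (0.10 log units; within the scatter), which showed only that this one exchange could not be told apart from noise. Replacing 3-methoxyphenyl with 3,4,5-trimethoxyphenyl on the same nitrogen gives a clear loss in this cell assay, seen as an at least 3.8-fold higher number from compound 2 to compound 3 (0.58 log units; beyond the scatter), and also as an at least 3.0-fold higher number from compound 1 to compound 3 (0.48 log units; beyond the scatter). This position is therefore not indifferent to what it carries: the two smaller groups cannot be told apart, while the larger trimethoxy-bearing ring is a weaker inhibitor than either, by an amount that is known only as a minimum.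

On these data alone, the true size of the loss stays open, as does whether both added methoxy groups are needed for it or one alone would produce it. Also open is how this ring would behave with an amine or a carboxylic acid in place of the methoxy groups, since the compounds shown carry only chloro and methoxy there.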